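A few compounds are considered here, and "the series" means these few. Any claim that something is new, unique, unknown or untested is made for them only; others in the source may bear on it.

Measured so far:
compound 1, `Cn1ncc(Cl)c1-c1cc(C(=O)N[C@H]2CNCC[C@@H]2c2ccc(C(F)(F)F)cc2)oc1Cl`: 127 nM
compound 2, `Cn1ncc(Cl)c1-c1cc(C(=O)N[C@@H]2CN[C@H](CC(=O)O)C[C@H]2c2ccc(Cl)c(Cl)c2)oc1Cl`: 1.94 nM
compound 3, `CC(=O)OCC[C@@H]1C[C@@H](c2ccc(F)c(F)c2)[C@H](NC(=O)c2cc(-c3c(Cl)cnn3C)c(Cl)o2)CN1`: 3.4 nM

In an assay for inhibition of RAC-alpha serine/threonine-protein kinase (Homo sapiens), read by HTRF, with a stated time of 1 h (a lower number here means a stronger inhibitor, a higher number a weaker inhibitor), compound 2 holds the lowest of the three numbers. Compound 3, with its own value given above, stands within the scatter of compound 2, so no order between these two can be read from the data. Going by the values given here, compound 1 lies far beyond the scatter, its value well above that of compound 2, but no single step links it to either of the others.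

Compound 4, `Cn1ncc(Cl)c1-c1cc(C(=O)N[C@@H]2CN[C@H](CCO)C[C@H]2c2ccc(Cl)c(Cl)c2)oc1Cl`, has not yet been measured in this assay. It differs from compound 2 in one place: hydroxymethyl in place of carboxy on a saturated chain carbon bound to a saturated ring carbon.

Among the compounds with values here, no measured pair shows this exact change, so the expectation rests on what the two nearest values show. Compound 3 carries no carboxy group on its chain and still gives a number within the scatter of compound 2, which suggests that a change of this kind need not move the number far. Compound 4 is therefore expected to give a number near that of compound 2, with a step of a 2.1-fold higher number from compound 2 to compound 4 (0.31 log units; beyond the scatter) toward a slightly higher number, possibly within the scatter. The estimate for compound 4 in this assay is 4 nM, within a range from 1.5 nM to 12 nM.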

Compound 4, half-maximal inhibitory concentration: 2.74 nM
Compound 4: middle estimate off by 1.5-fold (0.16 log units), on the high side; measured number inside the range.
By their numbers in this assay, from the lowest: compounds 2, 4 and 3 (each within the scatter of the next); then compound 1.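

In this assay the replacement of carboxy by hydroxymethyl gives a 1.4-fold higher number from compound 2 to compound 4 (0.15 log units; within the scatter) and so leaves no order between the two compounds. This is the first pair shown that differs in this one place alone, on a saturated chain carbon bound to a saturated ring carbon, and it shows that the number stays within the scatter when the carboxy group, with its double bond outside aromatic rings, gives way to a group with one heavy atom fewer and the same count of hydrogen-bond donors and acceptors. No measurement is at hand that bears on why the number holds across this change.

The compounds shown leave open whether an amine, a methyl ester or a longer chain ending in a hydroxyl group would keep the number at this level when placed on the same chain. They also leave open whether the change from carboxymethyl to 2-hydroxyethyl would read the same way with a single fluorine or a trifluoromethyl group in place of the two chlorines on the benzene ring of compound 2 and compound 4.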